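This account rests on a few compounds, and the source may have more. Where it says the series, first, only, none or still open, it means among the compounds named here.

Working notes on the series, read in a functional assay on J774.A1 cells (Mus musculus) for inhibition, read by Griess assay, with stated times of 1 h and 24 h; a higher number here means a weaker inhibitor, a lower number a stronger inhibitor: compound 2 (`O=C1CC(c2ccccc2O)Oc2ccccc21`) gives 71300 nM, the higher of the two numbers measured so far. Compound 1 (`O=C1CC(c2ccccc2OCc2ccccc2)Oc2ccccc21`) gives 23200 nM. Compound 3 (`CCOc1ccccc1C1CC(=O)c2ccccc2O1`) has not yet been measured and differs from compound 2 by one change: ethyl in place of hydrogen on an oxygen on an aromatic ring. This is ethyl in place of hydrogen on an oxygen on an aromatic ring, or hydroxy to ethoxy.

Among the compounds with values here, only one measured step bears on it, a 3.1-fold higher number from compound 1 to compound 2 (0.49 log units; beyond the scatter), where hydrogen replaces benzyl on that same oxygen. Read in reverse, it links a substituent on that oxygen with the lower number. Within the data shown here, no measured compound carries ethyl, so only part of that step is expected to carry over, in the same direction, and the shift may stay within the scatter in this assay. The expected step is a 1.9-fold lower number from compound 2 to compound 3 (0.27 log units; within the scatter). For compound 3 the estimated value is 38000 nM, with an expected range of 16000 nM to 85000 nM.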

Compound 3, half-maximal inhibitory concentration: 38800 nM
Estimate against measurement, compound 3: 1.0-fold (0.01 log units) below; the measured number falls inside the stated range.
By their numbers in this assay, from the lowest: compounds 1, 3 and 2 (each within the scatter of the next, the first and the last beyond it).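

In this assay the ethyl group on this oxygen gives a 1.8-fold lower number from compound 2 to compound 3 (0.26 log units; within the scatter) and so is not resolved from the free hydroxy compound, while methyl in place of phenyl on the saturated chain carbon gives a 1.7-fold higher number from compound 1 to compound 3 (0.22 log units; within the scatter) and is not resolved either. Compound 3 thus lies within the scatter of both compound 1 and compound 2, although those two stay apart, and a substituent on this oxygen no longer reads as a clear separation once it is as small as ethyl. No measurement at hand offers an explanation for these steps.

Going by these compounds, whether a longer chain such as butyl on this oxygen would move the number beyond the scatter stays open. So does the effect of placing an amine or a carboxylic acid on that chain.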